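Fluoro in place of hydrogen across two matched pairs

The source may report more compounds than this note shows. Statements on the series, on what has been measured and on what is new or still open speak of the compounds shown alone.

Compound 1 `O=C1Nc2ccccc2C1(c1c[nH]c2ccccc12)c1c[nH]c2ccccc12` and compound 2 `COc1ccc2c(C3(c4c[nH]c5cc(OC)ccc45)C(=O)Nc4ccccc43)c[nH]c2c1` share a common core; how the two cores differ is not broken down here. In a functional assay on SK-N-SH cells (Homo sapiens) for cytotoxicity, read by MTT assay, with a stated time of 48 h (a higher number here means a weaker inhibitor, a lower number a stronger inhibitor), compound 1 gives 11300 nM, while compound 2 gives 13600 nM, and these two values lie within the usual scatter of each other. Compound 3 `O=C1Nc2ccc(F)cc2C1(c1c[nH]c2ccccc12)c1c[nH]c2ccccc12` is derived from compound 1 by a single change: fluoro in place of hydrogen on an aromatic carbon. In this assay compound 3 gives 67300 nM, which corresponds to a 6.0-fold higher number from compound 1 to compound 3 (0.77 log units; beyond the scatter). Compound 4 `COc1ccc2c(C3(c4c[nH]c5cc(OC)ccc45)C(=O)Nc4ccc(F)cc43)c[nH]c2c1` has not yet been measured in this assay; it stands to compound 2 as compound 3 stands to compound 1, carrying (fluoro in place of hydrogen on an aromatic carbon), and the surroundings of the change read the same in both pairs. Among the compounds with values here, because the earlier step of a 6.0-fold higher number from compound 1 to compound 3 (0.77 log units; beyond the scatter) lies beyond the scatter, a step of similar size is expected from compound 2 to compound 4, namely a 4.8-fold higher number from compound 2 to compound 4 (0.68 log units; beyond the scatter), though it rests on only one measured pair. In this assay compound 4 is therefore estimated at 65000 nM, with a plausible range from 25000 nM to 160000 nM.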

Compound 4, half-maximal inhibitory concentration: 4100 nM
Compound 4: middle estimate off by 16-fold (1.20 log units), on the high side, outside the stated range (below it).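

In this assay, fluoro in place of hydrogen on an aromatic carbon gives a 3.3-fold lower number from compound 2 to compound 4 (0.52 log units; beyond the scatter), so the step seen on the core of compound 1 does not carry over to the core of compound 2 in either size or direction. The two steps run opposite ways, and the gap between them exceeds what scatter would account for: the same change on two cores in this assay, a 6.0-fold higher number (0.77 log units; beyond the scatter) from compound 1 to compound 3 and a 3.3-fold lower number (0.52 log units; beyond the scatter) from compound 2 to compound 4, 20-fold (1.30 log units) apart, beyond the scatter of two such steps This shows that, for these two pairs, the outcome of the change depends on the core that carries it, so a step measured on one core is a poor guide to the other; it does not show which feature of the cores is responsible, why the direction reverses, or what a third core would do.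

The compounds shown leave open whether the reversal is particular to fluoro or would also appear with chloro or an amine on the same aromatic carbon. They also leave open how either core would respond to a nitrile there, and whether such a group would follow compound 3 or compound 4.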